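Removing the Trifluoromethyl Group from a Hydroxamic Acid Cap

The source may hold more compounds than are shown below. What is called first, only, known or untested is meant among the compounds shown, and "the series" means these compounds.

Compound 1, `COc1ccc(CN2CC=C(CCC(=O)NO)C2=O)cc1`: 1720 nM
Compound 2, `O=C(CCC1=CCN(Cc2cccc(C(F)(F)F)c2)C1=O)NO`: 540 nM

Both compounds were tested in a functional assay on HCT-15 cells (Homo sapiens) for antiproliferative activity; on this read-out higher numbers stand for weaker inhibition of growth and lower numbers for stronger inhibition of growth. Among the measured compounds shown here, of the two numbers known, compound 2 gives the lower one, and compound 1 gives a higher number by a margin beyond the usual scatter, so compound 2 is the more potent of the pair. Compound 3, `O=C(CCC1=CCN(Cc2ccccc2)C1=O)NO`, has not yet been measured in this assay. It differs from compound 2 in one place: hydrogen in place of trifluoromethyl on an aromatic carbon. For the measured compounds named here, no measured pair shows what this particular change does, so the expectation rests only on the two numbers above. A modest weakening of growth inhibition is expected, with the step from compound 2 to compound 3 estimated at a 1.8-fold higher number from compound 2 to compound 3 (0.25 log units; within the scatter), a size that may or may not exceed the scatter. On that basis compound 3 is estimated to give 950 nM in this assay, with a plausible range from 320 nM to 2800 nM.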

Compound 3, concentration for 50% growth inhibition: 5370 nM
For compound 3 the middle estimate is 5.7-fold (0.75 log units) below the measured one; measured number outside the range, above it.
By their numbers in this assay, from the lowest: compound 2; then compound 1; then compound 3.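

In this assay the trifluoromethyl group on the aromatic carbon turns out to matter: putting hydrogen in its place gives a 9.9-fold higher number from compound 2 to compound 3 (1.00 log units; beyond the scatter) and so a clear weakening of growth inhibition. Methoxy also compares favourably with hydrogen, with a 3.1-fold higher number from compound 1 to compound 3 (0.49 log units; beyond the scatter) as the step in the same direction, so the ring carrying neither group is the weakest of the three compounds. Nothing measured here explains why either group outperforms hydrogen.

The compounds shown leave open whether a smaller group such as fluorine or methyl, or a nitrile or an amine, on the same aromatic carbon would match trifluoromethyl. They also leave open whether trifluoromethyl would give a similar number on a different carbon of the ring.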